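The compounds below may be only part of what the source reports. "The series", "measured", "known", "first", "only" and "open" are said of these compounds alone.

Of the compounds shown here, two have been measured for growth inhibition. Compound 1 `O=C(Nc1cccc(-n2cc(-c3ccncc3)c(-c3ccc(Cl)c(O)c3)n2)c1)Nc1ccc(Cl)c(Cl)c1` gives, in a functional assay on MDA-MB-468 cells (Homo sapiens) for inhibition, read by sulforhodamine B assay, with a stated time of 48 h (on this read-out lower numbers stand for stronger inhibition of growth and higher numbers for weaker inhibition of growth), a concentration for total growth inhibition of 4250 nM. Compound 2 `COc1cc(-c2nn(-c3cccc(NC(=O)Nc4ccc(Cl)c(C(F)(F)F)c4)c3)cc2-c2ccncc2)ccc1Cl` gives 4420 nM in this assay, which is the higher of the two numbers, though compound 1 sits so close to it that the two values show no difference beyond the usual scatter. Compound 3 `O=C(Nc1cccc(-n2cc(-c3ccncc3)c(-c3ccc(Cl)c(O)c3)n2)c1)Nc1ccc(Cl)c(C(F)(F)F)c1` has not yet been measured in this assay. It is obtained from compound 2 by one change: hydrogen in place of methyl on an oxygen on an aromatic ring. Because compound 1, which also carries a hydroxy on that position, gives 4250 nM, and compound 2 with its methoxy gives 4420 nM, the step from compound 2 to compound 3 is expected to be small and undirected, no larger than the scatter. Compound 3 is therefore estimated at 4000 nM in this assay, with an expected range from 1500 nM to 10000 nM, the implied step being a 1.1-fold lower number from compound 2 to compound 3 (0.04 log units; within the scatter).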

Compound 3, concentration for total growth inhibition: 1750 nM
The estimate for compound 3 lay 2.3-fold (0.36 log units) above the measured number; low and high end bracket the measured number.
By their numbers in this assay, from the lowest: compound 3; then compounds 1 and 2 (each within the scatter of the next).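

In this assay the change from methoxy to hydroxy gives a 2.5-fold lower number from compound 2 to compound 3 (0.40 log units; beyond the scatter) and so has a measurable effect on growth inhibition, which compounds 1 and 2 could not show, as they differ in two places. With the hydroxy kept, trifluoromethyl in place of chloro on an aromatic carbon gives a 2.4-fold lower number from compound 1 to compound 3 (0.39 log units; beyond the scatter) as well, so the close values of compounds 1 and 2 concealed two modest steps that offset each other. Nothing available gives a reason for either step.

From the compounds shown here alone, it remains open whether an amine in place of the hydroxy, or an ethoxy in place of the methoxy, would give a number like that of compound 3. The compounds shown also leave open whether the methoxy to hydroxy step keeps its size with chloro in place of trifluoromethyl.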